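The source may hold more compounds than are shown below. What is called first, only, known or untested is meant among the compounds shown, and "the series" means these compounds.

Measured so far in a functional assay on K562 cells (Homo sapiens); a lower number here means a stronger inhibitor, a higher number a weaker inhibitor:
- compound 3 `CN(C)c1nc(Br)nc2c1ncn2[C@@H]1C[C@@H](O)[C@H](CO)O1`: > 300 uM (a limit of the assay, not a number)
- compound 1 `CN(C)c1nc(N)c2ncn([C@@H]3C[C@@H](O)[C@H](CO)O3)c2n1`: > 300 uM (a limit)
- compound 2 `CSc1nc(SC)c2ncn([C@@H]3C[C@@H](O)[C@H](CO)O3)c2n1`: > 300 uM (a limit)

Compound 3 stands nowhere distinct: its value is a limit only, and the same holds for the other two, all three resting at the limit of > 300 uM in this assay, at which 3 of the 3 values shown sit. For the measured compounds named here, no pair of measured compounds differs in a single place, so no size of step can be read from this set.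

Compound 4 `Nc1nc(Br)nc2c1ncn2[C@@H]1C[C@@H](O)[C@H](CO)O1` is the next one to be run in this assay. The change is amino in place of dimethylamino on an aromatic carbon. Going by the values given here, with every value so far a limit, no direction is indicated; a step of a number no higher from compound 3 to compound 4 (the limit leaves the size open) is expected, which is none beyond the scatter. Compound 4 is expected near 300 uM, between 100 uM and 1000 uM.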

Compound 4, concentration for 50% inhibition: 83 uM
Beside the measured number, compound 4's estimate is 3.6-fold (0.56 log units) above it; measured number outside the range, below it.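

In this assay, for the compounds shown here, amino in place of dimethylamino on an aromatic carbon gives an at least 3.6-fold lower number from compound 3 to compound 4 (0.55 log units; beyond the scatter), and this is the first value in the set that is a number rather than a limit. At the other substituted carbon, a change from dimethylamino to bromo gives an at least 3.6-fold lower number from compound 1 to compound 4 (0.55 log units; beyond the scatter), so among these compounds only amino and bromo together leave the limit. Both steps start from a limit, so their full size stays unknown: the limit of > 300 uM in this assay, at which 3 of the 4 values shown sit.

Open, going by these compounds, is whether methylamino would sit closer to amino or to dimethylamino. Also open, on these data alone, is whether chloro or iodo could stand in place of bromo.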